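The source may hold more compounds than are shown below. What is called first, only, known or untested is meant among the compounds shown, and "the series" means these compounds.

Compounds measured so far:

Compound 1 `CC/C(=C(/c1ccc(/C=C/C(=O)O)cc1)c1ccc2[nH]ncc2c1)c1ccccc1`: 7.2 nM

Compound 2 `O=C(O)/C=C/c1ccc(/C(=C(/CCO)c2ccccc2)c2ccc3[nH]ncc3c2)cc1`: > 1000 nM

In a functional assay on MCF7 cells (Homo sapiens) for cytotoxicity, read by CellTiter-Glo, with a stated time of 5 days (a lower number here means a stronger inhibitor, a higher number a weaker inhibitor), compound 1 gives 7.2 nM. Among the two values shown, compound 1 holds the only real number; the other value is a limit. Compound 2 is reported only as > 1000 nM, which is a limit of the assay rather than a number (the limit of > 1000 nM in this assay, at which 1 of the 2 values shown sits). The step of an at least 130-fold higher number from compound 1 to compound 2 (2.14 log units; beyond the scatter) therefore stands for a large loss of potency when a hydroxy replaces a hydrogen on the saturated chain carbon.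

Compound 3 `CC/C(=C(/c1ccc(/C=C/C(=O)O)cc1)c1cnc2[nH]ncc2c1)c1ccccc1` keeps the chain of compound 1 unchanged and differs only in the aromatic group: a group of 9 heavy atoms (6 carbon, 3 nitrogen; one five-membered aromatic ring with 2 hetero atoms, one six-membered aromatic ring with 1 hetero atom) in place of a group of 9 heavy atoms (7 carbon, 2 nitrogen; one five-membered aromatic ring with 2 hetero atoms, one six-membered aromatic ring of carbon only), on a double-bonded chain carbon bound to an aromatic carbon and a double-bonded chain carbon. For the measured compounds named here, no measured step touches this part of the structure; the only measured step concerns the chain, not the ring system. The expectation for the ring change therefore rests on the fact that the chain, where the measured loss occurred, is left intact, and no shift beyond the scatter is assumed.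

Compound 3 is expected to give about 15 nM in this assay, within the range 5 nM to 60 nM, which corresponds to an expected step of a 2.1-fold higher number from compound 1 to compound 3 (0.32 log units; beyond the scatter).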

Compound 3, half-maximal inhibitory concentration: 302 nM
Estimate against measurement, compound 3: 20-fold (1.30 log units) below; measured number above the stated range.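

In this assay, replacing 1H-indazol-5-yl with a group that has a nitrogen in its six-membered aromatic ring gives a 42-fold higher number from compound 1 to compound 3 (1.62 log units; beyond the scatter), a large step. For the compounds shown here, until now, the only measured step lay in the chain; this one shows that the aromatic group on the double-bonded chain carbon also matters, even though the incoming group has the same number of heavy atoms and hydrogen-bond donors and differs in having one more hydrogen-bond acceptor. Nothing measured here explains why this single change in the ring costs so much potency.

The compounds shown leave open whether the loss depends on where the nitrogen sits in the six-membered ring, since only one placement appears here, and whether a fluorine or a methyl group on that ring would be tolerated as well as the plain ring of compound 1. They also leave open whether a change in the ring would have the same effect in a compound with a different chain, such as a longer chain in place of the ethyl chain of compound 1.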